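The source may hold more compounds than are shown below. What is called first, only, known or untested is meant among the compounds shown, and "the series" means these compounds.

The measured compounds were all tested in an ADME assay on MRC5 cells (Homo sapiens) for cytotoxicity, read by resazurin assay, with a stated time of 72 h; on this read-out lower numbers stand for stronger inhibition and higher numbers for weaker inhibition:

Compound 1 `O=[N+]([O-])c1cn2c(n1)OC(COc1ncc(-c3ccc(F)cc3)cn1)CC2` gives > 64000 nM, which is a limit of the assay and not a number.
Compound 2 `CC1(COc2cccc(-c3ccc(F)nc3F)n2)CCn2cc([N+](=O)[O-])nc2O1` gives > 64000 nM, again a limit of the assay.
Compound 3 `CC1(COCc2ccc(-c3ccc(F)cc3)cc2)CCn2cc([N+](=O)[O-])nc2O1` gives > 64000 nM, once more a limit of the assay.

Compound 3 therefore stands exactly where the two other measured compounds stand: at the limit, with no number reached (the limit of > 64000 nM in this assay, at which 3 of the 3 values shown sit). Among the compounds with values here, no two of the measured compounds differ in only one place, so no single step between them can be read off, and nothing can be said about how far any of the three lies beyond the limit.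

Compound 4 `CC1(COCc2ccc(OC(F)(F)F)cc2)CCn2cc([N+](=O)[O-])nc2O1` differs from compound 3 in one place: trifluoromethoxy in place of 4-fluorophenyl on an aromatic carbon. Within the data shown here, since every value so far is a limit, no measured step in this assay can be sized. The expectation for this change is none beyond the scatter, in either direction; the three measured compounds, carrying quite different groups at the corresponding end of the molecule, all sat at the limit.

For compound 4 the estimate is 70000 nM, within a range from 30000 nM to 150000 nM, with the assay most likely again reporting only a limit. The expected step that the limit leaves unreadable from compound 3 to compound 4 is thus essentially nothing.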

Compound 4, half-maximal inhibitory concentration: > 64000 nM
Compound 4: only a limit was reported (the forecaster's own chance of this, stated with the estimate: 85%); the middle value lies beyond the limit too.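

Compound 4 gives > 64000 nM, which is a limit of the assay and not a number. Compound 3 also sits at a limit, so no step between compound 3 and compound 4 can be read, and all the compounds shown stand together: the limit of > 64000 nM in this assay, at which 4 of the 4 values shown sit.

The compounds shown leave open how far any of them lies beyond that limit, and which structural change, if any, would bring a measurable value.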